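The source may report more compounds than this note shows. Statements on the series, on what has been measured and on what is new or still open speak of the compounds shown alone.

Measured compounds in an in vitro assay on CHO cells for displacement of a labelled ligand from Bombesin receptor subtype-3 (Homo sapiens), read by scintillation counting, with a stated time of 2 h; on this read-out lower numbers stand for stronger inhibition and higher numbers for weaker inhibition:
compound 1, `CCC(C)(C)Cc1c[nH]c(CCc2ccc(-c3cccc(N)n3)cc2)n1`: 7.3 nM
compound 2, `CCC(C)(C)Cc1c[nH]c(CCc2ccc(-c3ccncc3)cc2)n1`: 101 nM
compound 3, `CCC(C)(C)Cc1c[nH]c(CCc2ccc(-c3cccc(C#N)n3)cc2)n1`: 140 nM

Compound 3 gives the highest number of the three. Its nearest neighbour is compound 2, with a 1.4-fold higher number from compound 2 to compound 3 (0.14 log units; within the scatter), a gap within the scatter, so these two cannot be ordered. Its furthest is compound 1, with a 19-fold higher number from compound 1 to compound 3 (1.28 log units; beyond the scatter); the same picture appears in a 14-fold higher number from compound 1 to compound 2 (1.14 log units; beyond the scatter). Both large steps run from compound 1 to a compound lacking the amino group.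

Compound 4, `CCC(C)(C)Cc1c[nH]c(CCc2ccc(-c3cccc(C)n3)cc2)n1`, is not yet measured. It differs from compound 3 by methyl in place of cyano on an aromatic carbon. Among the measured compounds shown here, no measured step exchanges cyano for methyl, so the bearing evidence is indirect. The step from compound 1 to compound 3 shows that only the amino-bearing compound reaches a low number; the step from compound 2 to compound 3 shows that two different substituent patterns without amino sit within the scatter of one another. Methyl brings no donor and no acceptor, so nothing in the data points to a return toward compound 1. The expected step is a 1.4-fold lower number from compound 3 to compound 4 (0.15 log units; within the scatter), that is, nothing beyond the scatter, with the direction uncertain. Compound 4 is therefore estimated at 100 nM in this assay, within a range of 35 nM to 300 nM.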

Compound 4, half-maximal inhibitory concentration: 6.3 nM
The estimate for compound 4 lay 16-fold (1.20 log units) above the measured number; the measured number lies below the stated range.
By their numbers in this assay, from the lowest: compounds 4 and 1 (each within the scatter of the next); then compounds 2 and 3 (each within the scatter of the next).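

Working notes on this assay: the group next to the ring nitrogen matters far more than the earlier compounds could show, since replacing cyano with methyl alone gives a large step (a 22-fold lower number from compound 3 to compound 4 (1.35 log units; beyond the scatter)). A low number at this place does not depend on the amino group. Methyl, with 0 hydrogen-bond donors, cannot be ordered against amino (a 1.2-fold lower number from compound 1 to compound 4 (0.06 log units; within the scatter)). The 6-methylpyridin-2-yl group also stands well apart from pyridin-4-yl (a 16-fold lower number from compound 2 to compound 4 (1.20 log units; beyond the scatter)), although that step changes both the methyl group and the way the ring is attached, so it cannot assign the gain to either change.

No measurement available here explains why methyl and amino sit together while cyano sits so far from both. From the compounds shown here alone, it remains open whether ethyl, methoxy, chlorine or unsubstituted pyridin-2-yl would fall with methyl and amino or with cyano, and whether a dimethylamino group at this place would keep the low number.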